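Series notes: amine variation at the chain carbon, compound 4

A few compounds are considered here, and "the series" means these few. Any claim that something is new, unique, unknown or untested is made for them only; others in the source may bear on it.

Among the compounds with values here, in a functional assay on DLD-1 cells (Homo sapiens) for antiproliferative activity, read by sulforhodamine B assay, with a stated time of 48 h, tested at 10 uM (on this read-out higher numbers stand for more inhibition at the one concentration tested (going by the name of the read-out) and lower numbers for less inhibition), compound 2 `CCCCCCCCCCCCCC[C@H](OCOC)[C@H](CN(CC)CC)NC(=O)OC(C)(C)C` gives 46.2%, second highest of the three numbers so far. Its nearest neighbour is compound 3 `CCCCCCCCCCCCCC[C@H](OCOC)[C@H](CN(CCCC)CCCC)NC(=O)OC(C)(C)C`, which in this assay gives 56.1%; the change a number 9.9 percentage points higher from compound 2 to compound 3 (within the scatter) stays within the scatter. The furthest is compound 1 `CCCCCCCCCCCCCC[C@H](O)[C@H](CO[Si](c1ccccc1)(c1ccccc1)C(C)(C)C)NC(=O)OC(C)(C)C`, which in this assay gives 10.4%, a gap from compound 2 that lies beyond the scatter.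

Compound 4 `CCCCCCCCCCCCCC[C@H](OCOC)[C@H](CN1CCN(C)CC1)NC(=O)OC(C)(C)C` differs from compound 2 at one place: 4-methylpiperazin-1-yl in place of diethylamino on a saturated chain carbon, two bonds along the chain from an amide-type nitrogen. Within the data shown here, the only measured step at that position is the one from compound 2 to compound 3, where dibutylamino replaced diethylamino and the number moved by a number 9.9 percentage points higher from compound 2 to compound 3 (within the scatter), within the scatter. Among the measured compounds shown here, that step swapped one open-chain amine for another; no measured compound carries a ring at this position, so the present change has no direct precedent. Taking the single step at this position as the guide, the expectation is that compound 4 stays within the scatter of compound 2, with no step in either direction that can be trusted; the expected step is a number 3.2 percentage points lower from compound 2 to compound 4 (within the scatter).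

In this assay compound 4 is therefore estimated at 43%, with a range from 26% to 60%.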

Compound 4, a percentage reported as inhibition, at one concentration (the size of the read-out at that concentration, not a potency): 32%
For compound 4 the middle estimate is 11 percentage points above the measured one; low and high end bracket the measured number.
By their numbers in this assay, from the lowest: compound 1; then compound 4; then compounds 2 and 3 (each within the scatter of the next).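

With 4-methylpiperazin-1-yl in place of the open-chain amines, this assay shows a number 14.2 percentage points lower from compound 2 to compound 4 (beyond the scatter) and a number 24.1 percentage points lower from compound 3 to compound 4 (beyond the scatter) on the same saturated chain carbon, so the number at this position does depend on which amine is carried there. Within the data shown here, the earlier swap between open-chain amines, a number 9.9 percentage points higher from compound 2 to compound 3 (within the scatter), gave no such separation; the first steps beyond the scatter here come with a six-membered non-aromatic ring and a second ring nitrogen, which enter together in compound 4 and cannot be told apart. No evidence at hand accounts for these lower numbers.

The compounds shown leave open whether the ring itself or its added nitrogen goes with the lower number, and piperidin-1-yl and morpholin-4-yl at the same place would be the groups to read against compound 4. Also open, as far as these compounds go, is how a primary amine on that carbon would compare with the diethylamino group of compound 2 and the dibutylamino group of compound 3.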